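From 4-methylphenyl to 2-methylphenyl: compound 3 to compound 4

This account rests on a few compounds, and the source may have more. Where it says the series, first, only, none or still open, it means among the compounds named here.

In an ADME assay on CHO cells (Cricetulus griseus) for cytotoxicity, read by LDH release (a lower number here means a stronger inhibitor, a higher number a weaker inhibitor), compound 3 `Cc1ccc(CNC(=O)C(C)Oc2ccc(Cl)cc2Cl)cc1` gives 25000 nM and compound 1 `CC(Oc1ccc(Cl)cc1Cl)C(=O)NCc1ccc(Cl)cc1` gives 39000 nM. These two values lie within the scatter of each other, as the step of a 1.6-fold lower number from compound 1 to compound 3 (0.19 log units; within the scatter) shows. Compound 2 `CC(Oc1ccc(Cl)cc1Cl)C(=O)NCc1ccccc1Cl` reads > 100000 nM, which is a limit of the assay and not a number. Compound 3 therefore shares the low end of this small set with compound 1.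

Compound 4 `Cc1ccccc1CNC(=O)C(C)Oc1ccc(Cl)cc1Cl` has the same atoms as compound 3, joined differently: 2-methylphenyl in place of 4-methylphenyl on a saturated chain carbon bound to an amide-type nitrogen. Among the measured compounds shown here, the nearest precedent is the same shift made with chloro in place of methyl, an at least 2.5-fold higher number from compound 1 to compound 2 (0.40 log units; beyond the scatter). The step of an at least 4.0-fold lower number from compound 2 to compound 3 (0.60 log units; beyond the scatter) points the same way, although it also exchanges chloro for methyl. Both steps end at the limit, so they fix only a smallest size, and they rest on a single pair of positions. Since exchanging chloro for methyl stayed within the scatter in the step to compound 3, a modest rise in this assay is expected, and compound 4 could reach the limit.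

For compound 4 the estimated value is 60000 nM, with an expected range of 28000 nM to 100000 nM. This estimate amounts to an expected 2.4-fold higher number from compound 3 to compound 4 (0.38 log units; beyond the scatter).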

Compound 4, half-maximal inhibitory concentration: > 100000 nM
Compound 4: a limit, no number; the forecaster's own chance of this, stated with the estimate: 35%; middle value at least 1.6-fold (0.22 log units) away from the limit.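

In this assay, moving the methyl group from 4-methylphenyl to 2-methylphenyl gives an at least 4.0-fold higher number from compound 3 to compound 4 (0.60 log units; beyond the scatter), so the shift seen with the chlorophenyl pair now appears in a step that exchanges no chloro for methyl. Set against the 4-chlorophenyl group of compound 1, the same 2-methylphenyl group gives an at least 2.5-fold higher number from compound 1 to compound 4 (0.40 log units; beyond the scatter), which agrees with this reading, and in the two pairs shown the 2-substituted benzyl amide carries the higher reading, with no listed compound going against it. Compound 2 and compound 4 both end at a limit, so the step that joins them cannot be read and methyl and chloro cannot be ranked at this place: the limit of > 100000 nM in this assay, at which 2 of the 4 values shown sit.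

As far as these compounds go, since the readings for compound 2 and compound 4 are limits, the steps that reach them fix only a smallest size, and how far either compound lies beyond the limit stays unknown. From the compounds shown here alone, it also stays open whether a methoxy group or a carboxylic acid in place of the methyl of 2-methylphenyl would remain at the limit, or whether a longer chain between the amide-type nitrogen and the ring would bring the reading back within range.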